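Trifluoromethyl on the Phenoxy Ring of Compound 1

This account rests on a few compounds, and the source may have more. Where it says the series, first, only, none or still open, it means among the compounds named here.

Compound 1 `CCS(=O)(=O)Nc1ccc(Oc2ccccc2)c(-c2cn(C)c(=O)c3[nH]ccc23)c1`: 917 mL/min/kg in an ADME assay on microsomes from liver (Mus musculus) for metabolic stability; on this read-out higher numbers stand for fast clearance and lower numbers for slow clearance
Compound 2 `Cn1cc(-c2cc(S(N)(=O)=O)ccc2Oc2ccccc2)c2cc[nH]c2c1=O`: 517 mL/min/kg

Going by the values given here, only two compounds have been measured, and compound 1 and compound 2 sit within the scatter of each other: a 1.8-fold lower number from compound 1 to compound 2 (0.25 log units; within the scatter). Compound 3 `CCS(=O)(=O)Nc1ccc(Oc2ccc(C(F)(F)F)cc2)c(-c2cn(C)c(=O)c3[nH]ccc23)c1` has not been measured yet. It differs from compound 1 by trifluoromethyl in place of hydrogen on an aromatic carbon, on an aromatic carbon of a six-membered aromatic ring of carbon only. Among the compounds with values here, the single measured step, a 1.8-fold lower number from compound 1 to compound 2 (0.25 log units; within the scatter), changes a different part of the molecule and so does not bear on this change. With nothing to point either way, the expected step is a 1.1-fold lower number from compound 1 to compound 3 (0.06 log units; within the scatter), no change beyond the scatter. Compound 3 is therefore estimated at 800 mL/min/kg, with a range from 400 mL/min/kg to 1500 mL/min/kg.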

Compound 3, clearance: 2830 mL/min/kg
Compound 3: middle estimate off by 3.5-fold (0.55 log units), on the low side; measured number above the stated range.
By their numbers in this assay, from the lowest: compounds 2 and 1 (each within the scatter of the next); then compound 3.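

The phenoxy ring is not a silent place in this assay: trifluoromethyl in place of hydrogen on an aromatic carbon, para to a large group, gives a 3.1-fold higher number from compound 1 to compound 3 (0.49 log units; beyond the scatter). This is the first step shown that lies beyond the scatter, and it runs towards faster clearance. No measurement at hand accounts for the rise. From the compounds shown here alone, it remains open whether a single fluorine or chlorine atom, or a methoxy group, on this same carbon would give a rise of similar size, and whether trifluoromethyl would do the same on compound 2.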